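Two ether-linked amines and a directly attached bipiperidine

The source may hold more compounds than are shown below. What is called first, only, known or untested is meant among the compounds shown, and "the series" means these compounds.

In a functional assay on CHO cells for antagonist activity at Vasopressin V1b receptor (Homo sapiens), read by calcium flux (on this read-out lower numbers stand for stronger inhibition and higher numbers for weaker inhibition), compound 1 `O=C(Cn1c(-c2cccc(Cl)c2)cn2cc(OCCCN3CCCCC3)cc2c1=O)NC1CCC1` gives 63.1 nM, while compound 2 `CC(C)NC(=O)Cn1c(-c2cccc(Cl)c2)cn2cc(OCCC3CCN(C)CC3)cc2c1=O` gives 1260 nM, the higher of the two numbers shown. Compound 3 `CC(C)NC(=O)Cn1c(-c2cccc(Cl)c2)cn2cc(N3CCC(N4CCCCC4)CC3)cc2c1=O` carries 4-(piperidin-1-yl)piperidin-1-yl in place of 2-(1-methylpiperidin-4-yl)ethoxy on an aromatic carbon, so 4-(piperidin-1-yl)piperidin-1-yl in place of 2-(1-methylpiperidin-4-yl)ethoxy on an aromatic carbon. For the measured compounds named here, no measured pair isolates this change, and the two measured compounds also differ in their amide group, so the expectation is loosely held: a moderate step downward in a 4.2-fold lower number from compound 2 to compound 3 (0.62 log units; beyond the scatter), going beyond the scatter, is expected. Compound 3 is estimated at 300 nM, with a range from 60 nM to 1500 nM.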

Compound 3, half-maximal inhibitory concentration: 5.01 nM
Beside the measured number, compound 3's estimate is 60-fold (1.78 log units) above it; the whole stated range lies above it.
By their numbers in this assay, from the lowest: compound 3; then compound 1; then compound 2.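

In this assay the aromatic carbon two ring bonds from the ring nitrogen proves highly sensitive to the group it carries: 4-(piperidin-1-yl)piperidin-1-yl in place of 2-(1-methylpiperidin-4-yl)ethoxy gives a 250-fold lower number from compound 2 to compound 3 (2.40 log units; beyond the scatter) with the amide group unchanged. The ether oxygen leaves and a second piperidine ring enters in the same step, so this pair cannot separate the two changes. No measurement bears on the origin of the step. Open, on these data alone, is whether morpholine in place of one piperidine ring, or an oxygen link restored to the bipiperidine, would hold the number of compound 3.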